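A few compounds are considered here, and "the series" means these few. Any claim that something is new, unique, unknown or untested is made for them only; others in the source may bear on it.

The study tracks solubility in a physicochemical assay for solubility, read by nephelometry (a higher number here means a more soluble compound, a lower number a less soluble compound), across a shared core, seen in compound 1 `CC1(C)C(=O)N(c2ccc(SC(F)(F)F)cc2)C(=O)N1Cc1ccnc(C(=O)O)c1` and compound 2 `CC1(C)C(=O)N(c2ccc(SC(F)(F)F)cc2)C(=O)N1Cc1ccnc(F)c1`. In this assay compound 1 gives 0.142 ug/mL, the highest of the two numbers recorded, while compound 2 gives 0.032 ug/mL. For the measured compounds named here, the only step measured so far runs a 4.4-fold lower number from compound 1 to compound 2 (0.65 log units; beyond the scatter).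

Compound 3 `CC(C)Nc1cc(CN2C(=O)N(c3ccc(SC(F)(F)F)cc3)C(=O)C2(C)C)ccn1` has not yet been measured in this assay. It differs from compound 1 in one place: isopropylamino in place of carboxy on an aromatic carbon. Going by the values given here, the change that bears on it is the one from compound 1 to compound 2, where carboxy also left an aromatic carbon and the number fell by a modest amount beyond the scatter. Because that step was a 4.4-fold lower number from compound 1 to compound 2 (0.65 log units; beyond the scatter), a drop of comparable size is expected here, though isopropylamino is not fluoro and the two cases differ in what enters, so the range is wide. Compound 3 is therefore estimated at 0.04 ug/mL, between 0.01 ug/mL and 0.2 ug/mL, which corresponds to an expected step of a 3.6-fold lower number from compound 1 to compound 3 (0.55 log units; beyond the scatter).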

Compound 3, solubility: < 0.023 ug/mL
Compound 3: only a limit was reported (the forecaster's own chance of this, stated with the estimate: 10%); at least 1.7-fold (0.24 log units) between middle value and limit.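

For compound 3, this assay returned only a limit and not a number: the limit of < 0.023 ug/mL in this assay, at which 1 of the 3 values shown sits.

Even so, the limit is enough for a comparison with compound 1, since isopropylamino in place of carboxy on this aromatic carbon, next to the ring nitrogen, gives an at least 6.1-fold lower number from compound 1 to compound 3 (0.79 log units; beyond the scatter). With this second replacement, both groups shown in place of carboxy now end beyond the scatter from compound 1, so the earlier drop is no longer tied to fluoro alone. Isopropylamino in place of fluoro gives an at least 1.3-fold lower number from compound 2 to compound 3 (0.14 log units; that floor lies within the scatter), and with that floor inside the scatter, the result does not separate these two replacements from each other.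

The compounds shown leave open how far compound 3 actually lies beneath its limit, and so how large the step from carboxy to isopropylamino really is. They also leave open whether a primary amine, a hydroxyl group or a longer carbon chain on this same aromatic carbon would stay close to compound 2 and compound 3 or come nearer to compound 1.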